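A Carbamoyl Insertion and the Cytotoxicity of Compound 4

This account rests on a few compounds, and the source may have more. Where it says the series, first, only, none or still open, it means among the compounds named here.

compound 1 `Cc1cc(C)cc(S(=O)(=O)c2c(C(=O)NCc3cccc(F)c3F)[nH]c3ccc(Cl)cc23)c1` — > 51100 nM
compound 2 `Cc1cc(C)cc(S(=O)(=O)c2c(C(=O)NC(C)C(=O)NCc3ccco3)[nH]c3ccc(Cl)cc23)c1` — 24200 nM
compound 3 `Cc1cc(C)cc(S(=O)(=O)c2c(C(=O)NC(C)c3ccco3)[nH]c3ccc(Cl)cc23)c1` — > 54700 nM

In an ADME assay on MT4 cells (Homo sapiens) for cytotoxicity, read by MTT assay (a higher number here means that more compound is tolerated, a lower number that less compound is tolerated), compound 1 gives > 51100 nM, which is a limit of the assay and not a number. Compound 3 also gives only a limit, > 54700 nM. Compound 2 gives 24200 nM. Compound 1 therefore stands at the limit (the limit of > 51100 nM in this assay, at which 1 of the 3 values shown sits), and only compound 2 carries a number.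

Compound 4 `Cc1cc(C)cc(S(=O)(=O)c2c(C(=O)NCC(=O)NCc3ccccc3F)[nH]c3ccc(Cl)cc23)c1` is not yet measured. It differs from compound 1 as follows: (2-fluorobenzyl)carbamoyl in place of 2,3-difluorophenyl on a saturated chain carbon bound to an amide-type nitrogen.

The step that bears on this is an at least 2.1-fold lower number from compound 1 to compound 2 (0.32 log units; beyond the scatter), where a carbamoyl unit likewise entered. an at least 2.2-fold higher number from compound 2 to compound 3 (0.35 log units; beyond the scatter) points the same way, since removing that unit raised the number, while a step that the two limits leave unreadable from compound 1 to compound 3 is unreadable. Compound 4 is therefore expected to give a lower number than compound 1, an at least 2.0-fold lower number from compound 1 to compound 4 (0.31 log units; beyond the scatter), estimated at 25000 nM with a range of 12000 nM to 52000 nM.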

Compound 4, half-maximal cytotoxic concentration: > 47300 nM
Compound 4 ended at the assay's limit; the forecaster's own chance of this, stated with the estimate: 30%; at least 1.8-fold (0.27 log units) between middle value and limit.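

The carbamoyl unit does not by itself bring a number within reach in this assay: compound 4 carries (2-fluorobenzyl)carbamoyl and gives > 47300 nM, which is a limit of the assay and not a number. Among the compounds shown here, the one readable step is an at least 1.9-fold higher number from compound 2 to compound 4 (0.29 log units; that floor lies within the scatter), so this floor does not firmly separate the two carbamoyl compounds. The steps from compound 1 and compound 3 to compound 4 cannot be read.

Which part of the change from compound 2 to compound 4 matters remains open, since the methyl and furan-2-yl parts change together. Also open, as far as these compounds go, is whether a longer chain or a carboxylic acid in place of ((2-fluorobenzyl)carbamoyl)methyl would give a number.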